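The source may hold more compounds than are shown below. What is called first, only, known or untested is meant among the compounds shown, and "the series" means these compounds.

Measured so far in an ADME assay on MDBK cells (Bos taurus) for cytotoxicity, read by MTT assay, with a stated time of 96 h; a lower number here means that less compound is tolerated, a higher number that more compound is tolerated:
- compound 1 `Fc1ccc(NC(=S)Nc2cccc(C(F)(F)F)c2)cc1`: 41000 nM
- compound 2 `CSCCCNC(=S)Nc1cccc(C(F)(F)F)c1`: > 100000 nM (a limit of the assay, not a number)
- compound 3 `Fc1cccc(NC(=S)Nc2cccc(C(F)(F)F)c2)c1`: 10000 nM

Of the two true numbers, compound 3 holds the lower at 10000 nM. The other number belongs to compound 1 at 41000 nM. The entry for compound 2 is only a limit, > 100000 nM.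

Compound 4 `FC(F)(F)c1cccc(NC(=S)NCc2ccco2)c1` carries (furan-2-yl)methyl in place of 3-fluorophenyl on an amide-type nitrogen. Among the compounds with values here, no measured compound carries this group, so the nearest guide is the exchange between 3-(methylsulfanyl)propyl and 3-fluorophenyl, which gave an at least 10-fold lower number from compound 2 to compound 3 (1.00 log units; beyond the scatter). The exchange of 4-fluorophenyl for 3-(methylsulfanyl)propyl gave an at least 2.4-fold higher number from compound 1 to compound 2 (0.38 log units; beyond the scatter), and that of 4-fluorophenyl for 3-fluorophenyl gave a 4.1-fold lower number from compound 1 to compound 3 (0.61 log units; beyond the scatter). Each step away from 3-fluorophenyl thus points upward, so a higher number of modest size is expected in this assay. The expected change is a 4.0-fold higher number from compound 3 to compound 4 (0.60 log units; beyond the scatter). For compound 4 the estimate is 40000 nM, with an expected range of 13000 nM to 100000 nM.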

Compound 4, half-maximal cytotoxic concentration: > 100000 nM
Compound 4: a limit, no number (the forecaster's own chance of this, stated with the estimate: 25%); middle value at least 2.5-fold (0.39 log units) away from the limit.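

In this assay, compound 4 gives > 100000 nM, which is a limit of the assay and not a number. On the amide-type nitrogen, (furan-2-yl)methyl shows an at least 10-fold higher number from compound 3 to compound 4 (1.00 log units; beyond the scatter) and an at least 2.4-fold higher number from compound 1 to compound 4 (0.38 log units; beyond the scatter), so a group holding an aromatic ring can also go with a higher number, and among the compounds shown, true numbers remain confined to the fluorophenyl compounds, compound 1 and compound 3. The step from compound 2 to compound 4 cannot be read, since both entries are limits: the limit of > 100000 nM in this assay, at which 2 of the 4 values shown sit.

The compounds shown leave open whether the furan ring or the saturated chain carbon carries this shift, a question that a benzyl group on the same nitrogen would address. From the compounds shown here alone, how far compound 2 and compound 4 differ also stays open.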